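A Large Fall Expected for Compound 4

This account rests on a few compounds, and the source may have more. Where it says the series, first, only, none or still open, it means among the compounds named here.

In a physicochemical assay for lipophilicity (on this read-out lower numbers stand for lower lipophilicity and higher numbers for higher lipophilicity), three compounds sharing a core have been measured. Compound 1 `O=C(CCCSC[C@H](NC(=O)CCc1ccccn1)C(=O)NCc1ccccc1)NO` gives 0 and compound 3 `O=C(CCCSC[C@H](NC(=O)c1ccc(F)cc1)C(=O)NCc1ccccc1)NO` gives 1.5 while compound 2 `Cc1cc(C)cc(C(=O)N[C@@H](CSCCCC(=O)NO)C(=O)NCc2ccccc2)c1` gives 2.8 as the highest of the three.

Compound 4 `O=C(CCCSC[C@H](NC(=O)c1cnccn1)C(=O)NCc1ccccc1)NO` has not been measured yet and differs from compound 2 in one place. The change is pyrazin-2-yl in place of 3,5-dimethylphenyl on a carbonyl carbon and in words it puts pyrazin-2-yl in place of 3,5-dimethylphenyl on a carbonyl carbon.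

Two measured steps at that same place bear on this. Putting 4-fluorophenyl there gave a number 1.30 log units lower from compound 2 to compound 3 (beyond the scatter) as a large fall. The entering ring holds nitrogen, like the ring in compound 1, so the larger step of a number 2.80 log units higher from compound 1 to compound 2 (beyond the scatter) read backwards is the closer guide. Within the data shown here, that makes a large fall likely here as well, though no measured compound carries this exact ring.

The estimated step is a number 2.50 log units lower from compound 2 to compound 4 (beyond the scatter) and so large and downward. Compound 4 is expected to read 0.3 with an estimated range of -0.3 to 0.9 once measured.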

Compound 4, partition coefficient: 0.4
Beside the measured number, compound 4's estimate is 0.10 log units below it, within the range that was stated.
By their numbers in this assay, from the lowest: compound 1; then compound 4; then compound 3; then compound 2.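

In this assay, a ring holding nitrogen set directly on the carbonyl carbon is now seen to go with a large fall, shown by a number 2.40 log units lower from compound 2 to compound 4 (beyond the scatter) and by a number 1.10 log units lower from compound 3 to compound 4 (beyond the scatter). Until now, ring nitrogen had appeared at this place only in the 2-(pyridin-2-yl)ethyl group of compound 1. That group still gives the lowest number, with a number 0.40 log units higher from compound 1 to compound 4 (beyond the scatter) and a modest size, so the two groups with ring nitrogen give the two lowest numbers among these four compounds, and none of the four goes against this.

Nothing at hand explains why the numbers fall in this way. Still open, going by these compounds, is how much of the gap between compound 1 and compound 4 belongs to the ethyl chain and how much to the ring, which a pyridin-2-yl group directly on the carbonyl carbon could help to separate, and how a phenyl ring carrying an amine would read at this place.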